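Amide aryl variation on a shared chloro-substituted core

The source may report more compounds than this note shows. Statements on the series, on what has been measured and on what is new or still open speak of the compounds shown alone.

Measured so far in a functional assay on MCF7 cells (Homo sapiens) for antiproliferative activity, read by MTT assay, with a stated time of 72 h; on this read-out higher numbers stand for weaker inhibition and lower numbers for stronger inhibition:
Compound 1 `O=C(Nc1ccc(Cl)c(-c2nnc3c(Cl)cccn23)c1)c1ccccn1` gives 96400 nM.
Compound 2 `Cc1nc(C(=O)Nc2ccc(Cl)c(-c3nnc4c(Cl)cccn34)c2)cs1` gives only the assay limit > 100000 nM.
Compound 3 `O=C(Nc1ccc(Cl)c(-c2nnc3c(Cl)cccn23)c1)c1cccnc1` gives only the assay limit > 100000 nM.

Compound 3 therefore stands at the limit of this assay and not at a number. Going by the values given here, the series as a whole sits there or close to it: the limit of > 100000 nM in this assay, at which 2 of the 3 values shown sit, and the one numbered value, that of compound 1, lies just inside it. The two readable steps are floors only, an at least 1.0-fold higher number from compound 1 to compound 2 (0.01 log units; that floor lies within the scatter) and an at least 1.0-fold higher number from compound 1 to compound 3 (0.01 log units; that floor lies within the scatter), both within the scatter; the pair of limits leaves a step that the two limits leave unreadable from compound 2 to compound 3 unreadable.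

Compound 4 `O=C(Nc1ccc(Cl)c(-c2nnc3c(Cl)cccn23)c1)c1ccc(Cl)cc1` differs from compound 3 in one place: 4-chlorophenyl in place of pyridin-3-yl on a carbonyl carbon. No measured step in this series involves 4-chlorophenyl on the carbonyl carbon, so nothing shown speaks for or against it. What is shown is that three different aryl groups on that carbonyl all leave this assay at or just inside its limit, so for compound 4 no step beyond the scatter is expected in this assay, in either direction. The step this expectation implies is a number no higher from compound 3 to compound 4 (the limit leaves the size open). Compound 4 is estimated at 100000 nM, with a range from 40000 nM to 250000 nM, and a limit rather than a number is the more likely outcome.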

Compound 4, half-maximal inhibitory concentration: 58400 nM
Compound 4: middle estimate off by 1.7-fold (0.23 log units), on the high side; the measured number falls inside the stated range.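

Going by these compounds alone, a carbon-only aromatic ring bearing chlorine, the first such group on this carbonyl carbon, also gives a numbered value in this assay, so a numbered value at this position is not confined to pyridin-2-yl: compound 4 gives 58400 nM. The three new steps are an at least 1.7-fold lower number from compound 3 to compound 4 (0.23 log units; that floor lies within the scatter), an at least 1.7-fold lower number from compound 2 to compound 4 (0.23 log units; that floor lies within the scatter) and a 1.7-fold lower number from compound 1 to compound 4 (0.22 log units; within the scatter), the first two being floors set by limits, and none goes beyond the scatter. No group on this carbonyl carbon has yet produced a step beyond the scatter, and the series remains at or near one value:  the limit of > 100000 nM in this assay, at which 2 of the 4 values shown sit.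

On these data alone, whether a non-aromatic group on the carbonyl carbon, such as a piperidine with its ring amine or a longer alkyl chain ending in a carboxylic acid, would give a step beyond the scatter remains open. As far as these compounds go, it also remains open whether the chlorine of 4-chlorophenyl or its carbon-only ring accounts for the numbered value, as the change from pyridin-3-yl alters both at once.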